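This account rests on a few compounds, and the source may have more. Where it says the series, first, only, none or still open, it means among the compounds named here.

Working notes on the series, read in a functional assay on K562 cells (Homo sapiens) for inhibition; a higher number here means a weaker inhibitor, a lower number a stronger inhibitor:

- compound 1 `CCC(=O)OC1C(C(O)CO)OC2OC(C)(C)OC21` gives 2400000 nM
- compound 2 `CC(C)CC(=O)OC1C(C(O)CO)OC2OC(C)(C)OC21` gives 1000000 nM
- compound 3 `CC1(C)OC2OC(C(O)CO)C(OC(=O)C(C)(C)C)C2O1` gives 1500000 nM

Compound 3 stands within the scatter of both other compounds: a 1.5-fold higher number from compound 2 to compound 3 (0.18 log units; within the scatter) and a 1.6-fold lower number from compound 1 to compound 3 (0.20 log units; within the scatter). Within the data shown here, the only step beyond the scatter is modest: a 2.4-fold lower number from compound 1 to compound 2 (0.38 log units; beyond the scatter).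

The next compound is compound 4 `CC(=O)OC1C(C(O)CO)OC2OC(C)(C)OC21`, which carries methyl in place of tert-butyl on a carbonyl carbon, so that (tert-butyl)carbonyl becomes acetyl: methyl in place of tert-butyl on a carbonyl carbon.

Among the measured compounds shown here, no measured compound carries this acetyl. The closest guide is the step that exchanges ethyl and tert-butyl on the same carbonyl carbon, a 1.6-fold lower number from compound 1 to compound 3 (0.20 log units; within the scatter), read in reverse, and it does not leave the scatter. The step of a 2.4-fold lower number from compound 1 to compound 2 (0.38 log units; beyond the scatter) also points the same way, though it rests on a single pair. Compound 1 at 2400000 nM is therefore taken as the best reference for compound 4.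

A small move toward a higher number is expected: a 1.7-fold higher number from compound 3 to compound 4 (0.24 log units; within the scatter). Compound 4 is expected at 2600000 nM, with an estimated range of 1300000 nM to 5000000 nM.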

Compound 4, half-maximal inhibitory concentration: 3800000 nM
Beside the measured number, compound 4's estimate is 1.5-fold (0.16 log units) below it; measured number inside the range.
By their numbers in this assay, from the lowest: compounds 2, 3, 1 and 4 (each within the scatter of the next, the first and the last beyond it).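

In this assay the change on this carbonyl carbon now gives a step beyond the scatter between tert-butyl and methyl, a 2.5-fold higher number from compound 3 to compound 4 (0.40 log units; beyond the scatter), whereas tert-butyl and ethyl at the same place stayed within it. Against the isobutyl of compound 2 the gap is wider, a 3.8-fold higher number from compound 2 to compound 4 (0.58 log units; beyond the scatter), the largest step in the series, while a 1.6-fold higher number from compound 1 to compound 4 (0.20 log units; within the scatter) stays within the scatter, so methyl and ethyl on this carbonyl carbon cannot be told apart, and the trend from methyl toward larger groups is only partial, as compound 1 also lies within the scatter of compound 3. No measurement shown gives a reason for these steps.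

The compounds shown leave open whether a longer chain, a phenyl ring or a cyclohexyl ring on this carbonyl carbon would continue toward lower numbers or level off. They also leave open what an amine or a carboxylic acid in the acyl group would do, and how the free hydroxyl groups of the side chain on the shared core contribute, since every compound here keeps them unchanged.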